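A few compounds are considered here, and "the series" means these few. Any claim that something is new, unique, unknown or untested is made for them only; others in the source may bear on it.

Working notes on the series. Compound 1 `c1ccc(OCc2nc3c(OCCCN4CCCCC4)cccc3n2CCCC2CCN(CCC3CCCCC3)CC2)cc1` and compound 2 `c1ccc(CCCN2CCC(CCCn3c(COc4ccccc4)nc4c(OCCCN5CCCCC5)cccc43)CC2)cc1` share a common core and differ only in the terminal ring of the chain on the piperidine nitrogen. In an in vitro assay on AV12 cells for binding affinity to Neuropeptide Y receptor type 1 (Homo sapiens) (on this read-out lower numbers stand for stronger inhibition and higher numbers for weaker inhibition), compound 1 gives 0.285 nM, and compound 2 gives 0.361 nM. For the measured compounds named here, the step of a 1.3-fold higher number from compound 1 to compound 2 (0.10 log units; within the scatter) is within the scatter, so the two numbers cannot be told apart; compound 2 stands level with compound 1, the only other measured compound.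

Compound 3 `C(=C\c1ccccc1)\CN1CCC(CCCn2c(COc3ccccc3)nc3c(OCCCN4CCCCC4)cccc32)CC1` is the next member. Its change from compound 2 is 2-phenylethenyl in place of phenethyl on a saturated chain carbon bound to an amine nitrogen in a ring: the chain keeps its length and its terminal ring, and only a double bond is introduced into the linker. Going by the values given here, no measured step alters this part of the chain; the one step available, from compound 1 to compound 2, swapped the terminal ring and stayed within the scatter, so it bears on compound 3 only loosely. A step no larger than the scatter is therefore expected, with no direction favoured, as a 1.1-fold higher number from compound 2 to compound 3 (0.04 log units; within the scatter). Compound 3 is estimated at 0.4 nM, within 0.15 nM to 1.2 nM, in this assay.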

Compound 3, inhibition constant: 0.183 nM
For compound 3 the middle estimate is 2.2-fold (0.34 log units) above the measured one; the measured number falls inside the stated range.
By their numbers in this assay, from the lowest: compounds 3, 1 and 2 (each within the scatter of the next).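

In this assay, for the compounds shown here, the double bond brought into the linker gives a 2.0-fold lower number from compound 2 to compound 3 (0.30 log units; within the scatter), and this is the first step that alters the linker itself while the terminal ring stays in place; 2-phenylethenyl and phenethyl therefore cannot be told apart at this position, on a saturated chain carbon bound to an amine nitrogen in a ring. The comparison with the saturated ring, 2-phenylethenyl in place of cyclohexylmethyl, gives a 1.6-fold lower number from compound 1 to compound 3 (0.19 log units; within the scatter), so a change of the terminal ring and the linker together also yields no separable difference, and the three compounds stand level in this read-out. No independent measurement is at hand to account for these numbers.

Going by these compounds alone, it remains open whether any group on this chain would move the number beyond the scatter, since all three steps so far lie within it. A pyridine ring as the terminal ring, an alkyne in the linker, or a chain longer than 3-phenylprop-2-en-1-yl would each test how far this position reaches.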